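Thiazole side-chain replacement: from urea to cyanoacrylate

The compounds below may be only part of what the source reports. "The series", "measured", "known", "first", "only" and "open" are said of these compounds alone.

Measured so far in a functional assay with Oryctolagus cuniculus as the target; a higher number here means a weaker inhibitor, a lower number a stronger inhibitor:
- compound 1, `COc1ccc(-c2nc(/N=C(\N)N(C)C)sc2-c2ccc(OC)cc2)cc1`, compound 1 gives 37 nM
- compound 2, `COc1ccc(-c2nc(CNC(=O)N3CCOCC3)sc2-c2ccc(OC)cc2)cc1`, compound 2 gives 660 nM
- compound 3, `CNC(=O)NCc1nc(-c2ccc(OC)cc2)c(-c2ccc(OC)cc2)s1`, compound 3 gives 22 nM

Compound 3 has the lowest number of the three, but the step of a 1.7-fold lower number from compound 1 to compound 3 (0.23 log units; within the scatter) is within the scatter, so the two cannot be ordered. The step of a 30-fold lower number from compound 2 to compound 3 (1.48 log units; beyond the scatter) is large and beyond the scatter.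

Compound 4, `CCOC(=O)/C(C#N)=C/c1nc(-c2ccc(OC)cc2)c(-c2ccc(OC)cc2)s1`, differs from compound 3 by 2-cyano-2-(ethoxycarbonyl)ethenyl in place of ((methylcarbamoyl)amino)methyl on an aromatic carbon. Going by the values given here, none of the measured steps changes this group in the same way. What they do show is that this position is sensitive: an 18-fold higher number from compound 1 to compound 2 (1.25 log units; beyond the scatter) and a 30-fold lower number from compound 2 to compound 3 (1.48 log units; beyond the scatter) are both large, while a 1.7-fold lower number from compound 1 to compound 3 (0.23 log units; within the scatter) is not. The group that enters has no hydrogen-bond donors and is unlike any of the three measured side chains, so the account rests on the spread seen so far rather than on a direct parallel.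

Compound 4 is therefore expected to sit nearer the weaker end of the measured range; the expected step is a 23-fold higher number from compound 3 to compound 4 (1.36 log units; beyond the scatter). For compound 4 the estimate in this assay is 500 nM, with a range from 100 nM to 3000 nM.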

Compound 4, half-maximal inhibitory concentration: < 10 nM
Compound 4 ended at the assay's limit; the forecaster's own chance of this, stated with the estimate: 10%; middle value at least 50-fold (1.69 log units) away from the limit.
By their numbers in this assay, from the lowest: compounds 3 and 1 (each within the scatter of the next); then compound 2. At a limit, below all of these: compound 4.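

In this assay compound 4 stands at a limit of the assay and not at a number: the limit of < 10 nM in this assay, at which 1 of the 4 values shown sits.

Even so, the limit is enough to place it, with 2-cyano-2-(ethoxycarbonyl)ethenyl, which has 0 hydrogen-bond donors, on this aromatic carbon: the steps are an at least 2.2-fold lower number from compound 3 to compound 4 (0.34 log units; beyond the scatter), an at least 3.7-fold lower number from compound 1 to compound 4 (0.56 log units; beyond the scatter) and an at least 66-fold lower number from compound 2 to compound 4 (1.81 log units; beyond the scatter). The earlier compounds shown here had set the low end of the range at this position with compound 1 and compound 3, which lie within the scatter of each other, and compound 4 shows that a side chain with no urea and no hydrogen-bond donors can go beyond both.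

From the compounds shown here alone, how far compound 4 lies past the limit stays unknown, so the full size of these steps cannot be read. The entering group brings its ethyl ester, nitrile and double bond together, and the compounds shown do not tell which of these parts matters; a carboxylic acid in place of the ethyl ester, or a saturated chain in place of the ethenyl link, would be needed to separate them.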